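Rearranging the five-membered ring on the shared core

A few compounds are considered here, and "the series" means these few. Any claim that something is new, unique, unknown or untested is made for them only; others in the source may bear on it.

Compound 2 `Cn1cc(-c2ccccc2NCC2=NCCN2)cn1` stands second highest of the three measured numbers in a functional assay with Alpha-1A adrenergic receptor (Homo sapiens) as the target, read by calcium flux (a higher number here means a larger maximal response, a lower number a smaller maximal response), where compound 2 gives 39%. Its nearest neighbour, compound 3 `CCn1cc(-c2ccccc2NCC2=NCCN2)cn1`, gives 0%, and the furthest, compound 1 `CCn1ncnc1-c1ccccc1NCC1=NCCN1`, gives 107%. Compound 4 `Cn1ccnc1-c1ccccc1NCC1=NCCN1` is not yet measured; it differs from compound 2 by 1-methyl-1H-imidazol-2-yl in place of 1-methyl-1H-pyrazol-4-yl on an aromatic carbon. For the measured compounds named here, the only measured step that changes one place is a number 39 percentage points lower from compound 2 to compound 3 (beyond the scatter), and it alters the alkyl group on the ring nitrogen, not the ring itself, so it does not bear directly on this change. Going by the values given here, compound 1 carries a different five-membered ring and a different alkyl group at once, so no single step to it is counted; its values with compound 2 show only that such rings span a wide range in this assay. The step from compound 2 to compound 4 is therefore expected to be a number 26 percentage points higher from compound 2 to compound 4 (beyond the scatter), with considerable uncertainty. Compound 4 is estimated at 65%, within 20% to 110%.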

Compound 4, largest response reached (reported as maximal response), in percent of the reference or control that the assay uses: 88%
Beside the measured number, compound 4's estimate is 23 percentage points below it; the measured number falls inside the stated range.
By their numbers in this assay, from the lowest: compound 3; then compound 2; then compound 4; then compound 1.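

In this assay, for the compounds shown here, the change of the five-membered ring on this aromatic carbon gives a number 49 percentage points higher from compound 2 to compound 4 (beyond the scatter) and so shows for the first time that the ring itself, and not only the alkyl group on its nitrogen, moves the maximal response. The two rings hold the same atoms and the same counted hydrogen-bond donors and acceptors, so the difference between 1-methyl-1H-pyrazol-4-yl and 1-methyl-1H-imidazol-2-yl lies in how those atoms are joined and not in what they are. Nothing measured here explains this step.

Going by these compounds, whether ethyl in place of methyl on the imidazole nitrogen would lower the response, as in a number 39 percentage points lower from compound 2 to compound 3 (beyond the scatter) for the pyrazole, stays open. So does what a pyridin-2-yl ring or a plain amine would give on the same aromatic carbon.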